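Pyridin-2-yl in Place of Diethylaminophenyl on the Ring Nitrogen

A few compounds are considered here, and "the series" means these few. Any claim that something is new, unique, unknown or untested is made for them only; others in the source may bear on it.

Measured so far in a functional assay on HOS-TE85 cells (Homo sapiens) for inhibition, read by CCK-8 assay, with a stated time of 72 h; a lower number here means a stronger inhibitor, a higher number a weaker inhibitor:
Compound 1 `Cc1ccnc(N2C(=O)CS[C@@H]2c2cccc(C(=O)NCCCCn3cccn3)c2)c1` gives 21.9 nM.
Compound 2 `COc1ccccc1N1C(=O)CSC1c1cccc(C(=O)NCCCCc2ccc(Cl)cc2)c1` gives 78.6 nM.
Compound 3 `CCN(CC)c1ccc(N2C(=O)CSC2c2cccc(C(=O)NCCCCc3ccccc3)c2)cc1` gives > 1000 nM, which is a limit of this assay and not a number.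

Compound 3 thus stands at the limit of > 1000 nM in this assay, at which 1 of the 3 values shown sits. Compound 4 `O=C(NCCCCc1ccccc1)c1cccc(C2SCC(=O)N2c2ccccn2)c1` differs from compound 3 in a single place: pyridin-2-yl in place of 4-(diethylamino)phenyl on an amide-type nitrogen in a ring. Within the data shown here, no step between two measured compounds follows this change on its own, so the expectation rests on what the three values show: compound 1 gives 21.9 nM and compound 2 gives 78.6 nM. The step from compound 3 to compound 4 is therefore expected to move toward stronger inhibition, beyond the usual scatter, at an at least 16-fold lower number from compound 3 to compound 4 (1.22 log units; beyond the scatter). Compound 4 is estimated at 60 nM, within 15 nM to 300 nM.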

Compound 4, half-maximal inhibitory concentration: 19.7 nM
For compound 4 the middle estimate is 3.0-fold (0.48 log units) above the measured one; low and high end bracket the measured number.
By their numbers in this assay, from the lowest: compounds 4 and 1 (each within the scatter of the next); then compound 2. At a limit, above all of these: compound 3.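

Pyridin-2-yl in place of 4-(diethylamino)phenyl on the amide-type nitrogen in a ring gives an at least 50-fold lower number from compound 3 to compound 4 (1.70 log units; beyond the scatter) in this assay, the first step here that follows one change alone. The earlier compounds shown here differed in several places, so none of them could tie the potency to this position. The size of the step is a bound, and compound 3 stands at a limit, not a number: the limit of > 1000 nM in this assay, at which 1 of the 4 values shown sits.

From the compounds shown here alone, whether the shift depends on the pyridine ring nitrogen or on the loss of the diethylamino group stays open. A plain phenyl at this position would separate the two.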